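Adding a Hydroxypyrrolidine Amide to the Triazole Phenyl

The compounds below may be only part of what the source reports. "The series", "measured", "known", "first", "only" and "open" are said of these compounds alone.

Compound 1 `COc1ccccc1-n1cc(COc2c(/C=C\C(=O)O)ccc(OC)c2CC=C(C)C)nn1` gives 32600 nM in a functional assay on A-431 cells (Homo sapiens) for cytotoxicity, read by MTT assay, with a stated time of 24 h; a lower number here means a stronger inhibitor, a higher number a weaker inhibitor.
Compound 2 `COc1ccc(/C=C\C(=O)O)c(OCc2cn(-c3ccccc3)nn2)c1CC=C(C)C` gives 21200 nM in this assay.

Among the measured compounds shown here, compound 2 holds the lower of the two numbers, but its only neighbour is compound 1, and the step of a 1.5-fold lower number from compound 1 to compound 2 (0.19 log units; within the scatter) lies within the scatter, so the pair cannot be ranked. Compound 3 `COc1ccc(/C=C\C(=O)O)c(OCc2cn(-c3ccccc3C(=O)N3CCC(O)C3)nn2)c1CC=C(C)C` differs from compound 2 by (3-hydroxypyrrolidin-1-yl)carbonyl in place of hydrogen on an aromatic carbon. For the measured compounds named here, no measured step touches this change: the one step known, a 1.5-fold lower number from compound 1 to compound 2 (0.19 log units; within the scatter), concerns a methoxy and was small. Compound 3 is therefore expected to differ little from its parent, a 1.0-fold higher number from compound 2 to compound 3 (0.02 log units; within the scatter). The estimate for compound 3 is 22000 nM, between 8000 nM and 60000 nM.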

Compound 3, half-maximal inhibitory concentration: 31500 nM
The estimate for compound 3 lay 1.4-fold (0.16 log units) below the measured number; low and high end bracket the measured number.
By their numbers in this assay, from the lowest: compounds 2, 3 and 1 (each within the scatter of the next).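

Placing (3-hydroxypyrrolidin-1-yl)carbonyl in place of hydrogen on this aromatic carbon gives a 1.5-fold higher number from compound 2 to compound 3 (0.17 log units; within the scatter) in this assay, so a group of 8 heavy atoms at this position leaves the number within the scatter of its parent. Set against methoxy at the same carbon, the group gives a 1.0-fold lower number from compound 1 to compound 3 (0.01 log units; within the scatter), and hydrogen, methoxy and this amide cannot be ranked here. No evidence is available to explain this result. Going by these compounds, whether an amine, a carboxylic acid or a longer chain on this carbon would move the number beyond the scatter remains open. So does whether the pyrrolidine amide without its hydroxy group would read the same.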